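The compounds below may be only part of what the source reports. "The series", "measured", "known", "first", "only" and "open" are said of these compounds alone.

Measured in a functional assay on CEM-DNR-bulk cells (Homo sapiens), read by MTT assay, with a stated time of 72 h (a higher number here means a weaker inhibitor, a lower number a stronger inhibitor), all three readings being limits:
- compound 1 `Nc1nc(N)c2c(-c3ccco3)cn([C@@H]3O[C@H](CO)[C@@H](O)[C@H]3O)c2n1`: > 20000 nM
- compound 2 `Nc1nc(N)c2c(-c3ccsc3)cn([C@@H]3O[C@H](CO)[C@@H](O)[C@H]3O)c2n1`: > 20000 nM
- compound 3 `Cc1nc(N)c2c(-c3ccsc3)cn([C@@H]3O[C@H](CO)[C@@H](O)[C@H]3O)c2n1`: > 20000 nM

Compound 3 gives > 20000 nM, which is a limit and not a number. For the measured compounds named here, the series so far shows only (the limit of > 20000 nM in this assay, at which 3 of the 3 values shown sit), so no rank order can be drawn.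

The next change leads to compound 4 `C#Cc1cn([C@@H]2O[C@H](CO)[C@@H](O)[C@H]2O)c2nc(C)nc(N)c12`, with ethynyl in place of thiophen-3-yl on an aromatic carbon.

Going by the values given here, two measured steps bear on it, and neither has a readable size. Thiophen-3-yl in place of furan-2-yl at this same place gives a step that the two limits leave unreadable from compound 1 to compound 2. Methyl in place of amino gives a step that the two limits leave unreadable from compound 2 to compound 3. Neither step tests ethynyl, so any direction is an expectation with little support, and a modest gain in this assay is the most that seems reasonable. The expectation rests on compound 3 and its limit of > 20000 nM.

The expected step is an at least 1.1-fold lower number from compound 3 to compound 4 (0.04 log units; that floor lies within the scatter). For compound 4 the estimated value is 18000 nM, with an expected range of 3000 nM to 30000 nM.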

Compound 4, half-maximal inhibitory concentration: 12600 nM
Compound 4: the middle estimate sits 1.4-fold (0.15 log units) above what was measured, and the stated range covers the measured number.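

In this assay, for the compounds shown here, compound 4 gives 12600 nM, the first reading that is a number and not a limit, so this place on the shared core can give a readable result. Ethynyl in place of thiophen-3-yl gives an at least 1.5-fold lower number from compound 3 to compound 4 (0.20 log units; that floor lies within the scatter); the true size of this step stays unknown, and only this floor can be stated, since compound 3 is a limit. The single number still stands against a series held mostly at the limit, and the two earlier steps cannot be read: the limit of > 20000 nM in this assay, at which 3 of the 4 values shown sit.

As far as these compounds go, whether any of the activity depends on the methyl group of compound 4 stays open, as does how ethynyl would read with amino in its place. From the compounds shown here alone, how a longer chain or an amine would read at the ethynyl place also stays open.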